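Swapping Phenyl for Thiophene on Two Nucleoside Cores

This account rests on a few compounds, and the source may have more. Where it says the series, first, only, none or still open, it means among the compounds named here.

Compound 1 `COc1ncnc2c1c(-c1ccsc1)cn2[C@@H]1O[C@H](CO)[C@@H](O)[C@H]1O` and compound 2 `COc1ncnc2c1c(-c1ccccc1)cn2[C@@H]1O[C@H](CO)[C@@H](O)[C@H]1O` share one core, while compound 3 `Nc1nc2c(c(-c3ccccc3)cn2[C@@H]2O[C@H](CO)[C@@H](O)[C@H]2O)c(=O)[nH]1` and compound 4 `Nc1nc2c(c(-c3ccsc3)cn2[C@@H]2O[C@H](CO)[C@@H](O)[C@H]2O)c(=O)[nH]1` share another; the difference between the two cores is not broken down here. In a functional assay on A549 cells (Homo sapiens), read by MTT assay, with a stated time of 72 h (on this read-out lower numbers stand for stronger inhibition and higher numbers for weaker inhibition), compound 1 gives 5170 nM. Compound 2 gives > 20000 nM, which is a limit of the assay, namely (the limit of > 20000 nM in this assay, at which 1 of the 3 values shown sits). The change thiophen-3-yl in place of phenyl on an aromatic carbon therefore produced an at least 3.8-fold lower number from compound 2 to compound 1 (0.58 log units; beyond the scatter). Compound 3 gives > 100000 nM, again a limit, namely (the limit of > 100000 nM in this assay, at which 1 of the 3 values shown sits). Compound 4 carries the same change, (thiophen-3-yl in place of phenyl on an aromatic carbon), at the same place. Since compound 3 shows only > 100000 nM as a limit, even a comparable gain would leave compound 4 weak. Compound 4 is expected at about 50000 nM, a step of an at least 2.0-fold lower number from compound 3 to compound 4 (0.30 log units; that floor lies within the scatter), estimated between 12000 nM and 200000 nM.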

Compound 4, half-maximal inhibitory concentration: > 20000 nM
Compound 4: no number, only a limit (the forecaster's own chance of this, stated with the estimate: 50%); the middle value lies beyond the limit too.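

Compound 3 and compound 4 both give only a limit of the assay, not a number, and the step between them cannot be read. Going by these compounds, whether thiophen-3-yl in place of phenyl lowers the number on this core remains open.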